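The compounds below may be only part of what the source reports. "The series", "measured", "known", "first", "only" and "open" are said of these compounds alone.

Measured in a functional assay on MCF7 cells (Homo sapiens) for inhibition, read by MTT assay, with a stated time of 72 h; on this read-out lower numbers stand for stronger inhibition and higher numbers for weaker inhibition:
- compound 1 `Cc1ccc(C(C)C)c(OCc2cn(-c3ccccc3)nn2)c1`: 29900 nM
- compound 2 `Cc1ccc(C(C)C)c(OCc2cn(-c3ccc(O)cc3)nn2)c1`: 45400 nM

With compound 2 at 45400 nM, the two numbers lie within the scatter of each other. Compound 3 `Cc1ccc(C(C)C)c(OCc2cn(-c3ccccc3Cl)nn2)c1` is the next to be read, with 2-chlorophenyl in place of 4-hydroxyphenyl on an aromatic nitrogen. For the measured compounds named here, the only measured step that bears on this is the hydroxy-for-hydrogen change, a 1.5-fold higher number from compound 1 to compound 2 (0.18 log units; within the scatter). Going by the values given here, no measured compound carries chlorine, so no step beyond the scatter is expected in this assay. The expected step is a 1.5-fold lower number from compound 2 to compound 3 (0.18 log units; within the scatter). For compound 3 the estimated value is 30000 nM, with an expected range of 12000 nM to 70000 nM.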

Compound 3, half-maximal inhibitory concentration: 15600 nM
The estimate for compound 3 lay 1.9-fold (0.28 log units) above the measured number, within the range that was stated.
By their numbers in this assay, from the lowest: compounds 3, 1 and 2 (each within the scatter of the next, the first and the last beyond it).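

In this assay, for the compounds shown here, 2-chlorophenyl in place of 4-hydroxyphenyl on the aromatic nitrogen gives a 2.9-fold lower number from compound 2 to compound 3 (0.46 log units; beyond the scatter) and is the first step here to pass beyond the scatter. Chloro in place of hydrogen alone gives a 1.9-fold lower number from compound 1 to compound 3 (0.28 log units; within the scatter) and stays within it, so compound 1 cannot be separated from compound 2 or from compound 3. Nothing available explains the step. Going by these compounds, whether the lower number depends on chlorine itself or on where it stands on the phenyl remains open. So does what a methoxy group, an amine or a carboxylic acid would do on this ring.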